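A Cyclopropylethyl Ether in Place of a Methoxymethylethyl Ether

The source may report more compounds than this note shows. Statements on the series, on what has been measured and on what is new or still open speak of the compounds shown alone.

Of the compounds shown here, three sharing one aminoquinoline-type core have been measured in an assay on cells with melanin-concentrating hormone receptor 1 (Homo sapiens) as the target, read by radioligand binding; on this read-out higher numbers stand for weaker inhibition and lower numbers for stronger inhibition. Compound 1 `Nc1ccc2cccc(OCC3CC4CCC3C4)c2n1` gives 137 nM, compound 2 `COCC(C)Oc1cccc2ccc(N)nc12` gives 606 nM, and compound 3 `CNc1ccc2cccc(OC(C)CC(C)(C)C)c2n1` gives 310 nM. Compound 2 thus carries the highest of the three numbers, although its gap to compound 3 stays within the usual scatter of repeated measurements, and only its gap to compound 1 lies beyond it.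

Compound 4 `Nc1ccc2cccc(OCCC3CC3)c2n1` has not yet been measured in this assay . It differs from compound 2 in one place: 2-cyclopropylethyl in place of 1-(methoxymethyl)ethyl on an oxygen on an aromatic ring.

Among the compounds with values here, no step between measured compounds matches this change, so the expectation rests on what the three values show. Compound 1 and compound 3, whose groups on the ring oxygen are built of carbon only, give lower numbers than compound 2, with compound 1 reading 137 nM and compound 3 reading 310 nM. On that basis a move toward a lower number is expected, of a size that may or may not clear the scatter, described by a 2.2-fold lower number from compound 2 to compound 4 (0.34 log units; beyond the scatter). Compound 4 is therefore estimated to give 280 nM in this assay , with a range from 110 nM to 700 nM.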

Compound 4, half-maximal inhibitory concentration: 492 nM
Compound 4: middle estimate off by 1.8-fold (0.24 log units), on the low side, and the stated range covers the measured number.
By their numbers in this assay, from the lowest: compound 1; then compounds 3, 4 and 2 (each within the scatter of the next).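

In this assay, within the data shown here, the exchange of 1-(methoxymethyl)ethyl for 2-cyclopropylethyl on the oxygen on the aromatic ring gives a 1.2-fold lower number from compound 2 to compound 4 (0.09 log units; within the scatter), the first step at this position that can be read in one place. Both groups hold 5 heavy atoms, so at this size, removing the hydrogen-bond acceptor of the leaving group and bringing in a three-membered carbon ring does not separate the two compounds beyond the scatter, and a group built of carbon only is not enough by itself to do so. The all-carbon group of compound 1, at 137 nM, therefore cannot be taken as evidence for carbon-only groups in general, and nothing among the data bears on why the exchange of groups leaves the number within the scatter.

The compounds shown leave open whether a larger ring system is what sets compound 1 apart, since a cyclohexylmethyl group or a longer chain ending in cyclopropyl would test this on the same core. They also leave open how an amine or a carboxylic acid at the end of the chain on the ring oxygen would read in this assay.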